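Replacing isoquinolin-4-yl with 2,3-dimethylphenyl

A few compounds are considered here, and "the series" means these few. Any claim that something is new, unique, unknown or untested is made for them only; others in the source may bear on it.

Compound 1 `CC1(C)CCC[C@]2(C)[C@@H](CC[C@@](C)(O)/C=C/c3ccccc3)[C@](C)(O)CC[C@@H]12`: 121 nM
Compound 2 `CC1(C)CCC[C@]2(C)[C@@H](CC[C@@](C)(O)/C=C/c3cncc4ccccc34)[C@](C)(O)CC[C@@H]12`: 3900 nM
Compound 3 `COc1cccc(OC)c1/C=C/[C@](C)(O)CC[C@@H]1[C@@]2(C)CCCC(C)(C)[C@@H]2CC[C@@]1(C)O`: 4000 nM

In a functional assay on PC-3 cells (Homo sapiens) for cytotoxicity, read by MTT assay, with a stated time of 48 h (on this read-out lower numbers stand for stronger inhibition and higher numbers for weaker inhibition), compound 2 gives 3900 nM. Its number cannot be told apart from that of compound 3, with a 1.0-fold higher number from compound 2 to compound 3 (0.01 log units; within the scatter). It stands far from the number of compound 1, with a 32-fold higher number from compound 1 to compound 2 (1.51 log units; beyond the scatter).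

The open question concerns compound 4 `Cc1cccc(/C=C/[C@](C)(O)CC[C@@H]2[C@@]3(C)CCCC(C)(C)[C@@H]3CC[C@@]2(C)O)c1C`, which has not yet been measured. The change is 2,3-dimethylphenyl in place of isoquinolin-4-yl on a double-bonded chain carbon bound to a double-bonded chain carbon. Among the compounds with values here, no measured compound carries 2,3-dimethylphenyl, so the evidence is indirect. Within the data shown here, two measured steps bear on it, both large and both starting from the plain phenyl of compound 1: a 32-fold higher number from compound 1 to compound 2 (1.51 log units; beyond the scatter) and a 33-fold higher number from compound 1 to compound 3 (1.52 log units; beyond the scatter). Both of the other groups tested on this double-bonded chain carbon thus ended at about the same number, and neither compound goes against that among these three. The new group resembles the 2,6-dimethoxyphenyl of compound 3 in being a substituted phenyl, so compound 4 is expected to stay near that level. The expected step is a 2.0-fold lower number from compound 2 to compound 4 (0.29 log units; within the scatter), which means no clear change is anticipated. The range is left wide on the low side, since compound 1 reaches 121 nM with an unsubstituted phenyl. For compound 4 the estimated value is 2000 nM, with an expected range of 400 nM to 6000 nM.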

Compound 4, half-maximal inhibitory concentration: 3500 nM
Compound 4: the middle estimate sits 1.8-fold (0.24 log units) below what was measured; low and high end bracket the measured number.
By their numbers in this assay, from the lowest: compound 1; then compounds 4, 2 and 3 (each within the scatter of the next).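

In this assay, the 2,3-dimethylphenyl group of compound 4 cannot be told apart from the two earlier replacements, with a 1.1-fold lower number from compound 2 to compound 4 (0.05 log units; within the scatter) and a 1.1-fold lower number from compound 3 to compound 4 (0.06 log units; within the scatter), both within the scatter. The large gap to the plain phenyl also holds, with a 29-fold higher number from compound 1 to compound 4 (1.46 log units; beyond the scatter), so three different groups on this double-bonded chain carbon now share one level, well apart from compound 1. What compound 4 adds is that this level does not depend on a hetero atom in the group: isoquinolin-4-yl carries a nitrogen and 2,6-dimethoxyphenyl carries oxygens, whereas 2,3-dimethylphenyl is carbon only, has no hydrogen-bond acceptor and has one aromatic ring rather than two. Nothing among the data given explains why these groups sit together or why the plain phenyl stands apart.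

The compounds shown leave open whether a phenyl bearing only one methyl or one fluorine would stay near compound 1 at 121 nM or join the other three. They also do not tell how a pyridine ring or a phenyl carrying an amine or a carboxylic acid would behave on this carbon.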